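Removing a Fluorine from Compound 3: Expected Cytotoxicity

A few compounds are considered here, and "the series" means these few. Any claim that something is new, unique, unknown or untested is made for them only; others in the source may bear on it.

Measured compounds:
compound 1 `CCOC(=O)/C(O)=C/C(=O)c1cn(Cc2cc(F)cc(F)c2)c2cccc(OC)c12` — 34700 nM
compound 2 `COc1cccc2c1c(C(=O)/C=C(\O)C(=O)O)cn2Cc1ccccc1F` — 70500 nM
compound 3 `CCOC(=O)/C(O)=C/C(=O)c1cn(Cc2ccc(F)cc2F)c2cccc(OC)c12` — 65500 nM

In an ADME assay on MT4 cells (Homo sapiens) for cytotoxicity, read by MTT assay (a lower number here means that less compound is tolerated, a higher number that more compound is tolerated), compound 3 gives 65500 nM, a number that lies within the scatter of compound 2 and of compound 1 alike. Compound 4 `CCOC(=O)/C(O)=C/C(=O)c1cn(Cc2ccccc2F)c2cccc(OC)c12` is not yet measured; it differs from compound 3 by hydrogen in place of fluoro on an aromatic carbon. Within the data shown here, the only measured step that bears on a change among fluorine substituents on this benzyl group is a 1.9-fold higher number from compound 1 to compound 3 (0.28 log units; within the scatter), which did not move the number beyond the scatter. Compound 2, the acid bearing the same 2-fluorobenzyl group, gives 70500 nM. Compound 4 is therefore expected to show no step beyond the scatter, a 1.1-fold lower number from compound 3 to compound 4 (0.02 log units; within the scatter), with an estimate of 62000 nM and a range from 30000 nM to 125000 nM.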

Compound 4, half-maximal cytotoxic concentration: 63300 nM
Estimate against measurement, compound 4: 1.0-fold (0.01 log units) below, within the range that was stated.
By their numbers in this assay, from the lowest: compounds 1, 4, 3 and 2 (each within the scatter of the next, the first and the last beyond it).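

At this position, meta to a fluoro group and para to a large group, hydrogen in place of fluoro leaves the number in this assay within the scatter (a 1.0-fold lower number from compound 3 to compound 4 (0.01 log units; within the scatter)). With the 2-fluorobenzyl group, the ethyl ester also lies within the scatter of the acid (a 1.1-fold lower number from compound 2 to compound 4 (0.05 log units; within the scatter)), and 2-fluorophenyl within that of 3,5-difluorophenyl (a 1.8-fold higher number from compound 1 to compound 4 (0.26 log units; within the scatter)). Nothing at hand explains these results. On these data alone, whether a chlorine, a methoxy group or an amine at this position would move the number beyond the scatter stays open.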